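Carbonyl substituent change in a urotensin-2 receptor series

The source may report more compounds than this note shows. Statements on the series, on what has been measured and on what is new or still open speak of the compounds shown alone.

Among the compounds with values here, compound 1 `Cc1cccc(C(=O)OC(CCN(C)C)c2ccc(Cl)cc2)c1C` and compound 2 `Cc1c(Cl)cccc1C(=O)NC(CCN(C)C)c1ccc(Cl)cc1` are the two compounds measured so far in an assay on NIH3T3 cells with Urotensin-2 receptor (Homo sapiens) as the target; on this read-out lower numbers stand for smaller maximal responses and higher numbers for larger maximal responses. Compound 1 gives 91% in this assay, and compound 2 gives 142%. Compound 1 thus stands lowest of the two numbers; compound 2 is the nearest and lies beyond the scatter above it. Within the data shown here, the two structures differ in more than one place, so no single step is drawn between them, and only the pair of values is noted.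

Compound 3 `Cc1ccccc1NC(=O)OC(CCN(C)C)c1ccc(Cl)cc1` has not yet been measured in this assay. Against compound 1 the change is (2-methylphenyl)amino in place of 2,3-dimethylphenyl on a carbonyl carbon. Among the measured compounds shown here, no step of this kind exists among the measured compounds, so neither direction nor size of the effect on the largest response can be read from the data. Absent such a step, the working expectation is a step from compound 1 to compound 3 that stays within the usual scatter, a number 9 percentage points higher from compound 1 to compound 3 (within the scatter), taking compound 1 at 91% as the anchor. Compound 3 is therefore estimated to give 100% in this assay, with a range of 60% to 140%.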

Compound 3, largest response reached (reported as efficacy), in percent of the reference or control that the assay uses: 176%
Estimate against measurement, compound 3: 76 percentage points below; measured number above the stated range.
By their numbers in this assay, from the lowest: compound 1; then compound 2; then compound 3.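

In this assay, the carbonyl carbon bearing the oxygen proves to be a place where the substituent strongly affects the largest response: (2-methylphenyl)amino in place of 2,3-dimethylphenyl gives a number 85 percentage points higher from compound 1 to compound 3 (beyond the scatter). The two groups match in their 8 heavy atoms and in one six-membered aromatic ring of carbon only, yet the entering group has 1 nitrogen and 1 hydrogen-bond donor that the leaving group lacks, and it carries one methyl group fewer. A large step can therefore accompany a replacement that leaves the heavy-atom count unchanged, although nothing measured here explains the rise.

The step bundles the added amino nitrogen with the lost methyl group, so the share of each remains unresolved. A (2,3-dimethylphenyl)amino group would keep the nitrogen and restore the methyl group, while a (2-methylphenyl)methyl group would put a carbon where the nitrogen stands, and the compounds shown do not tell how the largest response would follow either replacement.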